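The source may report more compounds than this note shows. Statements on the series, on what has been measured and on what is new or still open speak of the compounds shown alone.

Measured compounds in a functional assay on CHO cells for activation of 5-hydroxytryptamine receptor 1D (Homo sapiens), read by GTPgammaS binding; on this read-out lower numbers stand for an effect already at smaller amounts and higher numbers for an effect only at larger amounts of compound:
compound 1 `c1ccc(CN2CCN(CCCc3c[nH]c4ccc(-n5cnnc5)cc34)CC2)nc1` gives 0.3 nM
compound 2 `c1c[nH]c(CN2CCN(CCCc3c[nH]c4ccc(-n5cnnc5)cc34)CC2)n1` gives 2 nM
compound 3 `NC(=O)C(c1ccccc1)N1CCN(CCCc2c[nH]c3ccc(-n4cnnc4)cc23)CC1` gives 0.2 nM

Compound 3 holds the lowest of the three numbers. Its gap to compound 1, a 1.5-fold lower number from compound 1 to compound 3 (0.18 log units; within the scatter), lies within the scatter, so the two cannot be ranked against each other; its gap to compound 2, a 10-fold lower number from compound 2 to compound 3 (1.00 log units; beyond the scatter), lies beyond the scatter. The remaining measured step, a 6.7-fold higher number from compound 1 to compound 2 (0.82 log units; beyond the scatter), is likewise beyond the scatter. All three steps alter only the group on the amine nitrogen in the ring.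

Compound 4 `CN(C)C(=O)C(c1ccccc1)N1CCN(CCCc2c[nH]c3ccc(-n4cnnc4)cc23)CC1` differs from compound 3 by dimethylamino in place of amino on a carbonyl carbon. Among the compounds with values here, no measured step touches the carbonyl or its amino group, so none of them bears directly on this change; the measured steps show only that the group on the amine nitrogen in the ring shifts the numbers within a modest range. For compound 4 a step of a 2.0-fold higher number from compound 3 to compound 4 (0.30 log units; within the scatter) is therefore expected in this assay, that is, nothing clearly beyond the scatter. Compound 4 is estimated at 0.4 nM, with a range from 0.1 nM to 2 nM.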

Compound 4, half-maximal effective concentration: 0.8 nM
Estimate against measurement, compound 4: 2.0-fold (0.30 log units) below, within the range that was stated.
By their numbers in this assay, from the lowest: compounds 3 and 1 (each within the scatter of the next); then compound 4; then compound 2.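

In this assay, within the data shown here, the carbonyl substituent is not a silent position: dimethylamino in place of amino on a carbonyl carbon gives a 4.0-fold higher number from compound 3 to compound 4 (0.60 log units; beyond the scatter), a modest step but the first measured change at this site. The change replaces a group with one hydrogen-bond donor by one with none and adds two carbons, so the two differences travel together in this single pair and cannot be separated. No measurement at hand explains the step.

The compounds shown leave open whether methylamino on the same carbonyl carbon would give an intermediate number, which would indicate how the step builds from one methyl to two. Also open, as far as these compounds go, is how pyrrolidin-1-yl or a carboxylic acid in place of the carbamoyl would read, and whether the step holds with pyridin-2-yl on the shared core.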